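The source may report more compounds than this note shows. Statements on the series, on what has been measured and on what is new or still open speak of the compounds shown alone.

Measured so far in an ADME assay on microsomes from liver (Rattus norvegicus) for metabolic stability; a higher number here means that more of the compound is left, a lower number that less of the compound is left:
Compound 1, `C/C(CN)=C(/F)CN(C[C@H]1Cc2ccccc2CN1)[C@H]1CCCc2cccnc21`, 72%
Compound 2, `C/C(=C/CN(C[C@H]1Cc2ccccc2CN1)[C@H]1CCCc2cccnc21)CN`, 1%

Compound 2 stands lowest of the two numbers; its nearest neighbour is compound 1, and the step of a number 71 percentage points lower from compound 1 to compound 2 (beyond the scatter) is large. Compound 3, `C/C(=C/CN)CN(C[C@H]1Cc2ccccc2CN1)[C@H]1CCCc2cccnc21`, has the same atoms as compound 2, joined differently: a group of 5 heavy atoms (4 carbon, 1 nitrogen; no ring) in place of a group of 5 heavy atoms (4 carbon, 1 nitrogen; no ring), on a saturated chain carbon bound to an amine nitrogen. Among the measured compounds shown here, the only measured step, the one from compound 1 to compound 2, swaps a fluorine-bearing group for one without fluorine and therefore does not bear directly on the rearrangement from compound 2 to compound 3; it shows only that changes at this place can move this assay strongly. For the measured compounds named here, with no directly comparable step, compound 3 is expected to stay near compound 2, and the step of a number 7 percentage points higher from compound 2 to compound 3 (within the scatter) is estimated to be small. Compound 3 is therefore expected to give 8%, within a range from 1% to 30%.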

Compound 3, percent of the compound remaining: 2%
The estimate for compound 3 lay 6 percentage points above the measured number, and the stated range covers the measured number.
By their numbers in this assay, from the lowest: compounds 2 and 3 (each within the scatter of the next); then compound 1.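

In this assay the rearrangement of the group of 5 heavy atoms, on a saturated chain carbon bound to an amine nitrogen, gives a number 1 percentage points higher from compound 2 to compound 3 (within the scatter), so joining these same atoms differently leaves the number unchanged within the scatter. The step of a number 70 percentage points lower from compound 1 to compound 3 (beyond the scatter) is large and matches the earlier drop, so two differently joined groups without fluorine now both stand far from the fluorine-bearing group of compound 1, and none of the three compounds goes against this. No measurement on hand explains these numbers.

Among the compounds shown here, whether the fluorine atom on the chain is enough by itself for the higher number remains open, since compound 1 is the only compound that carries it. Also open, from the compounds shown here alone, is how a chlorine atom in that place, or a longer chain ending in the amine, would behave.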